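Bromo for Methyl on the Sulfonyl Aryl Ring

A few compounds are considered here, and "the series" means these few. Any claim that something is new, unique, unknown or untested is made for them only; others in the source may bear on it.

Compound 1 `CC(=O)N(C)c1ccc2[nH]c(-c3n[nH]c4ccccc34)cc2n1` gives 10300 nM in a functional assay on KB cells (Homo sapiens) for antiproliferative activity, read by MTT assay, with a stated time of 72 h; on this read-out lower numbers stand for stronger inhibition and higher numbers for weaker inhibition.
Compound 2 `CCC(=O)N(C)c1ccc2[nH]c(-c3n[nH]c4ccccc34)cc2n1` gives 9300 nM.
Compound 3 `Cc1ccc(S(=O)(=O)N(C)c2ccc3[nH]c(-c4n[nH]c5ccccc45)cc3n2)cc1` gives 9500 nM.

The three measured compounds share one core and differ only in the group on the methyl-bearing nitrogen. Compound 3 has the second highest of the three numbers, and both of its neighbours lie within the scatter: a 1.1-fold lower number from compound 1 to compound 3 (0.04 log units; within the scatter) and a 1.0-fold higher number from compound 2 to compound 3 (0.01 log units; within the scatter). The remaining step, a 1.1-fold lower number from compound 1 to compound 2 (0.04 log units; within the scatter), is likewise within the scatter.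

Compound 4 `CN(c1ccc2[nH]c(-c3n[nH]c4ccccc34)cc2n1)S(=O)(=O)c1ccc(Br)cc1` differs from compound 3 by bromo in place of methyl on an aromatic carbon. Going by the values given here, none of the measured steps touches this ring position, and every measured step was within the scatter, so no step beyond the scatter is expected: no change at the digits printed from compound 3 to compound 4 (within the scatter). Compound 4 is therefore estimated at 9500 nM, with a range from 4000 nM to 22000 nM.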

Compound 4, half-maximal inhibitory concentration: 7150 nM
Compound 4: the middle estimate sits 1.3-fold (0.12 log units) above what was measured; the range from low to high includes it.
By their numbers in this assay, from the lowest: compounds 4, 2, 3 and 1 (each within the scatter of the next).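

On this aromatic carbon, bromo in place of methyl gives a 1.3-fold lower number from compound 3 to compound 4 (0.12 log units; within the scatter) in this assay, so the first change made on this ring stays within the scatter. The (4-bromophenyl)sulfonyl group likewise stays within the scatter of both amides, with a 1.3-fold lower number from compound 2 to compound 4 (0.11 log units; within the scatter) for propanoyl and a 1.4-fold lower number from compound 1 to compound 4 (0.16 log units; within the scatter) for acetyl. Nothing available accounts for the size of these steps.

As far as these compounds go, whether an amine or a carboxylic acid on this ring carbon would produce a step beyond the scatter remains open. So does the effect of removing the methyl from the nitrogen that carries the sulfonyl group.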